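Trading a hydroxycyclobutylmethyl for a hydroxycyclohexyl amine

The compounds below may be only part of what the source reports. "The series", "measured", "known", "first", "only" and "open" are said of these compounds alone.

Compound 1 `N#Cc1cnc(NCc2cnccc2C(F)(F)F)cc1NC[C@H]1C[C@@H](O)C1` was examined in an assay on isolated protein for inhibition of protein kinase C delta type (Homo sapiens), read by TR-FRET, with a stated time of 2 h (on this read-out higher numbers stand for weaker inhibition and lower numbers for stronger inhibition), where compound 1 gives 4200 nM. Of the two numbers recorded this is the lowest, yet the companion compound 2 `N#Cc1cnc(NCc2ccccc2C(F)(F)F)cc1N[C@H]1CC[C@@H](O)CC1` stands close by: in this assay compound 2 gives 4500 nM, a gap that lies within the usual scatter, so the two cannot be ranked against each other. Compound 3 `N#Cc1cnc(NCc2cnccc2C(F)(F)F)cc1N[C@H]1CC[C@H](O)CC1` has not yet been measured. It differs from compound 1 in one place: 4-hydroxycyclohexyl in place of (3-hydroxycyclobutyl)methyl on a nitrogen on an aromatic ring. Going by the values given here, no step between two measured compounds isolates this change, so its size has to be judged from what the two values show. Compound 2 already carries the 4-hydroxycyclohexyl group, alongside a different aromatic part, and its number sits beside that of compound 1. On that basis the exchange of the (3-hydroxycyclobutyl)methyl group for the 4-hydroxycyclohexyl group is expected to be small, of the size a 1.1-fold lower number from compound 1 to compound 3 (0.02 log units; within the scatter), with no direction beyond the scatter. Compound 3 is accordingly expected to give 4000 nM in this assay, within a range from 1400 nM to 12000 nM.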

Compound 3, half-maximal inhibitory concentration: 6500 nM
The estimate for compound 3 lay 1.6-fold (0.21 log units) below the measured number; low and high end bracket the measured number.
By their numbers in this assay, from the lowest: compounds 1, 2 and 3 (each within the scatter of the next).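

Going by these compounds alone, with compound 3, the exchange of (3-hydroxycyclobutyl)methyl for 4-hydroxycyclohexyl on a nitrogen on an aromatic ring can be read on its own for the first time, with the rest of the core of compound 1 unchanged. In this assay this exchange gives a 1.5-fold higher number from compound 1 to compound 3 (0.19 log units; within the scatter) and so sets no order between the two groups. At this place, on this core, a four-membered ring carried on a methyl link and a six-membered ring can therefore stand in for one another without a step beyond the usual scatter, and nothing given here offers a reason for the size of this step.

The compounds shown leave open whether any group at this place would move the number beyond the scatter, for instance an amine in place of the hydroxyl group, a longer chain ending in a hydroxyl group, or a piperidine ring in place of the cyclohexyl ring. Within the data shown here, they also leave open whether the same exchange would read alike on a core with a different aromatic part, since the one compound with such a part differs from compound 3 in more than one place.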